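The compounds below may be only part of what the source reports. "The series", "measured", "known", "first", "only" and "open" are said of these compounds alone.

Two related compounds have been measured in a functional assay on HepG2 cells (Homo sapiens) for cytotoxicity, read by MTT assay, with a stated time of 72 h; a higher number here means a weaker inhibitor, a lower number a stronger inhibitor. Compound 1, with the structure `COc1c(OCCCCN2CCN(C)CC2)cc(O)c2c(=O)cc(-c3ccc(Cl)cc3)oc12`, gives 3750 nM. Compound 2, with the structure `O=c1cc(-c2ccccc2)oc2c(OCCCN3CCCC3)c(OCc3ccccc3)cc(O)c12`, gives 2660 nM. These two numbers sit within the usual scatter of each other, so on what has been measured neither compound is set apart from the other.

Compound 3, with the structure `CN(C)CCCCOc1c(OCc2ccccc2)cc(O)c2c(=O)cc(-c3ccccc3)oc12`, has not yet been measured. It differs from compound 2 in one place: (dimethylamino)methyl in place of pyrrolidin-1-yl on a saturated chain carbon, three bonds along the chain from an oxygen on an aromatic ring. One amine is swapped for another on the same chain, and nothing else on the shared core moves. Among the compounds with values here, no measured pair that makes this exact swap is available, so there is no recorded step to lean on. The expectation is therefore that the change produces no step beyond the scatter in this assay. Compound 3 is estimated at 2700 nM, with a likely range from 1300 nM to 5600 nM, which means an expected step of a 1.0-fold higher number from compound 2 to compound 3 (0.01 log units; within the scatter).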

Compound 3, half-maximal inhibitory concentration: 2090 nM
For compound 3 the middle estimate is 1.3-fold (0.11 log units) above the measured one, and the stated range covers the measured number.
By their numbers in this assay, from the lowest: compounds 3, 2 and 1 (each within the scatter of the next).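

In this assay, putting (dimethylamino)methyl in place of pyrrolidin-1-yl gives a 1.3-fold lower number from compound 2 to compound 3 (0.10 log units; within the scatter), so at this place on the chain the five-membered ring can give way to an open-chain amine with no step beyond the scatter. Cut one bond further out, the same change reads 3-(pyrrolidin-1-yl)propyl to 4-(dimethylamino)butyl, which means that the ring and the chain length change together in this single pair. No supporting measurement is available to explain the result.

A 4-(pyrrolidin-1-yl)butyl chain or a 3-(dimethylamino)propyl chain would pull those two changes apart, and the compounds shown include neither. Going by these compounds, it also remains open whether a different end group, such as a morpholine ring or a carboxylic acid, would give a step beyond the scatter.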